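The compounds below may be only part of what the source reports. "The series", "measured", "known", "first", "only" and "open" are said of these compounds alone.

Measured compounds in a functional assay on PC-3 cells (Homo sapiens) for cytotoxicity, read by MTT assay; on this read-out lower numbers stand for stronger inhibition and higher numbers for weaker inhibition:

Compound 1 `COc1cc(/C=C/C(=O)c2sc(Nc3cccc(Cl)c3)nc2C)cc(OC)c1OC` sits at a limit of the assay, > 25000 nM.
Compound 2 `COc1cc(/C=C/C(=O)c2sc(Nc3ccc(Cl)c(Cl)c3)nc2C)cc(OC)c1OC` gives 19300 nM.
Compound 3 `COc1cc(/C=C/C(=O)c2sc(Nc3ccccc3)nc2C)cc(OC)c1OC` sits at a limit of the assay, > 25000 nM.

Compound 3 thus stands at the top of the range shown, where a number was not obtained (the limit of > 25000 nM in this assay, at which 2 of the 3 values shown sit). Compound 4 `COc1cc(/C=C/C(=O)c2sc(Nc3ccccc3C)nc2C)cc(OC)c1OC` differs from it by methyl in place of hydrogen on an aromatic carbon.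

No measured step adds a methyl; the shown steps change chloro substituents on the anilino ring. From compound 1 to compound 2 an at least 1.2-fold lower number from compound 1 to compound 2 (0.11 log units; that floor lies within the scatter). From compound 2 to compound 3 an at least 1.2-fold higher number from compound 2 to compound 3 (0.11 log units; that floor lies within the scatter). From compound 1 to compound 3 a step that the two limits leave unreadable from compound 1 to compound 3. All three steps are small or unreadable and leave this end of the series at or near the limit. A single methyl on the anilino ring is expected to move compound 4 no further than the scatter, so compound 4 most likely again returns only a limit. The expected step from compound 3 to compound 4 is a step that the limit leaves unreadable from compound 3 to compound 4. Compound 4 is therefore estimated at 30000 nM, ranging from 15000 nM to 60000 nM.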

Compound 4, half-maximal inhibitory concentration: > 25000 nM
Compound 4: a limit, no number; the forecaster's own chance of this, stated with the estimate: 70%; the middle value lies beyond the limit too.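

In this assay, the methyl of compound 4 is the only group shown ortho to a large group on the anilino ring, and it brings no readable gain over the unsubstituted phenyl of compound 3; the steps from compound 3 and from compound 1 to compound 4 cannot be read, as both ends are limits. Against the 3,4-dichlorophenyl group, 2-methylphenyl gives an at least 1.2-fold higher number from compound 2 to compound 4 (0.11 log units; that floor lies within the scatter). This position therefore adds no sized effect, and the ceiling now covers more of the series: the limit of > 25000 nM in this assay, at which 3 of the 4 values shown sit.

As far as these compounds go, how far compound 1, compound 3 and compound 4 lie past that limit stays unknown, so the size of the methyl change remains open. From the compounds shown here alone, whether an amine or a carboxylic acid at the same place on the anilino ring would give a number also stays open.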